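Amide to amine on the shared core: compound 4

The source may report more compounds than this note shows. Statements on the series, on what has been measured and on what is new or still open speak of the compounds shown alone.

Three compounds share one core and differ only in the acyl group. Compound 1 `CC(C)CC(=O)Nc1ncc(-c2cccc(Cl)c2)c(-c2ccccc2)n1` gives 56% in an assay on CHO cells for displacement of a labelled ligand from adenosine receptor A1 (Homo sapiens), read by scintillation counting, with a stated time of 1 h, tested at 1 uM; on this read-out higher numbers stand for more inhibition at the one concentration tested (going by the name of the read-out) and lower numbers for less inhibition. Compound 2 `O=C(Nc1ncc(-c2cccc(Cl)c2)c(-c2ccccc2)n1)C1CCC1` gives 52% in this assay, and compound 3 `O=C(Nc1ncc(-c2cccc(Cl)c2)c(-c2ccccc2)n1)C1CCCC1` gives 47% in this assay. Compound 3 has the lowest of the three numbers, but the step of a number 9 percentage points lower from compound 1 to compound 3 (within the scatter) and the step of a number 5 percentage points lower from compound 2 to compound 3 (within the scatter) are both within the scatter, as is a number 4 percentage points lower from compound 1 to compound 2 (within the scatter), so the three values are not distinguished.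

Compound 4 `Clc1cccc(-c2cnc(NC3CCCC3)nc2-c2ccccc2)c1` is reached from compound 3 by the change (cyclopentyl in place of cyclopentylcarbonyl on a nitrogen on an aromatic ring). Within the data shown here, all three measured steps concern swaps on a carbonyl carbon that keeps the carbonyl; none of them removes it, so no measured step bears on the move to cyclopentylamino, and no direction for this assay can be read from them. For compound 4 the expected value in this assay is estimated at 38%, within an expected range of 5% to 70%. This estimate corresponds to an expected step of a number 9 percentage points lower from compound 3 to compound 4 (within the scatter), with little confidence in either direction.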

Compound 4, a percentage reported as inhibition, at one concentration (the size of the read-out at that concentration, not a potency): > 80%
Compound 4: no number, only a limit; the forecaster's own chance of this, stated with the estimate: 0%; at least 42 percentage points between middle value and limit.
By their numbers in this assay, from the lowest: compounds 3, 2 and 1 (each within the scatter of the next). At a limit, above all of these: compound 4.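

Taking out the carbonyl, so that cyclopentylamino replaces (cyclopentylcarbonyl)amino on the shared core, gives a number at least 33 percentage points higher from compound 3 to compound 4 (beyond the scatter) in this assay. The comparisons with the other two amides run the same way, with a number at least 28 percentage points higher from compound 2 to compound 4 (beyond the scatter) and a number at least 24 percentage points higher from compound 1 to compound 4 (beyond the scatter), so at this nitrogen on an aromatic ring, removing the carbonyl moves the read-out beyond the scatter, whereas the swaps among the acyl groups stayed within it. The reading for compound 4 is a limit of the assay and not a number: the limit of > 80% in this assay, at which 1 of the 4 values shown sits.

From the compounds shown here alone, how far compound 4 lies past that limit stays open, so the full size of these steps is unknown. Also open, going by these compounds, is whether an isobutylamino or cyclobutylamino group on the shared core would behave as cyclopentylamino does.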